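Benzyl sulfanyl triazoles on liver cancer cells: a halogen swap

A few compounds are considered here, and "the series" means these few. Any claim that something is new, unique, unknown or untested is made for them only; others in the source may bear on it.

Measured compounds:
compound 1, `Clc1ccccc1CSc1nnc(-c2ccc3c(c2)OCCO3)n1-c1ccccc1`, 970 nM
compound 2, `Fc1ccc(CSc2nnc(-c3ccc4c(c3)OCCO4)n2-c2ccccc2)cc1`, 1020 nM

Both compounds were tested in a functional assay on HepG2 cells (Homo sapiens) for antiproliferative activity, read by MTT assay, with a stated time of 24 h; a higher number here means a weaker inhibitor, a lower number a stronger inhibitor. Compound 1 shows the lower of the two numbers, yet its nearest neighbour is compound 2, and the step of a 1.1-fold higher number from compound 1 to compound 2 (0.02 log units; within the scatter) lies within the scatter, so the two compounds cannot be set apart on these data.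

Compound 3, `Fc1ccc(CSc2nnc(-c3ccc4c(c3)OCCO4)n2-c2ccccc2)c(F)c1`, has not yet been tested in this assay. It differs from compound 1 in one place: 2,4-difluorophenyl in place of 2-chlorophenyl on a saturated chain carbon bound to a sulfur. Among the compounds with values here, the only measured step that bears on this change is the one from compound 1 to compound 2, where a 4-fluorophenyl took the place of the same 2-chlorophenyl on the same saturated chain carbon bound to a sulfur, and that step, a 1.1-fold higher number from compound 1 to compound 2 (0.02 log units; within the scatter), did not leave the scatter. Within the data shown here, a second fluorine on the ring entering here has no measured counterpart, so nothing in the data points to a shift in either direction. The step is therefore expected to be a 1.0-fold higher number from compound 1 to compound 3 (0.01 log units; within the scatter), no larger than the scatter, and compound 3 is estimated at 1000 nM, with a range from 500 nM to 2000 nM.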

Compound 3, half-maximal inhibitory concentration: 1960 nM
Compound 3: the middle estimate sits 2.0-fold (0.29 log units) below what was measured; low and high end bracket the measured number.
By their numbers in this assay, from the lowest: compounds 1, 2 and 3 (each within the scatter of the next, the first and the last beyond it).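

At this place, on a saturated chain carbon bound to a sulfur, the exchange of the aryl group is no longer without a readable effect: in this assay, 2,4-difluorophenyl in place of 2-chlorophenyl gives a 2.0-fold higher number from compound 1 to compound 3 (0.31 log units; beyond the scatter), a modest step but the first among these compounds to leave the scatter. The added fluoro on an aromatic carbon, taken alone, gives a 1.9-fold higher number from compound 2 to compound 3 (0.28 log units; within the scatter), which stays within the scatter, so compound 2 and compound 3 cannot be set apart, and the second fluorine cannot be named as the sole source of the separation between compound 1 and compound 3. Nothing available explains the difference between compound 1 and compound 3.

The compounds shown carry only halogens on this ring, so they leave open how a plain unsubstituted phenyl, or a ring bearing a methoxy group, an amine or a carboxylic acid, would read in this assay. They also leave open whether a longer chain between the sulfur and the ring would keep the numbers of compound 1 and compound 2 or move them beyond the scatter.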